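Removing a methyl between two ring nitrogens in a fused core

The source may hold more compounds than are shown below. What is called first, only, known or untested is meant among the compounds shown, and "the series" means these compounds.

Compound 1: `Cc1nc(C)n2c(=O)n(C)ncc12` — > 48000 nM
Compound 2: `C=CCn1ncc2c(C)nc(C)n2c1=O` — 73000 nM
Compound 3: `C=CCn1ncc2cnc(C)n2c1=O` — > 48000 nM

Among the measured compounds shown here, in a functional assay for inhibition, with Homo sapiens as the target (a lower number here means a stronger inhibitor, a higher number a weaker inhibitor), compound 2 gives 73000 nM, the only true number among the three measured compounds. For compound 1 the assay reports only a limit, > 48000 nM. For compound 3 the assay likewise reports only a limit, > 48000 nM. The step that the limit leaves unreadable from compound 1 to compound 2 and the step that the limit leaves unreadable from compound 2 to compound 3 are therefore both unreadable in size, since two of the three values sit at the limit (the limit of > 48000 nM in this assay, at which 2 of the 3 values shown sit).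

Compound 4, `C=CCn1ncc2c(C)ncn2c1=O`, is not yet measured. It differs from compound 2 by hydrogen in place of methyl on an aromatic carbon. For the measured compounds named here, the only measured step of the same kind, hydrogen in place of methyl on an aromatic carbon, is the step from compound 2 to compound 3, and its size cannot be read. No readable step bears on the change, so the expected step in this assay is estimated as none beyond the scatter, a 1.0-fold higher number from compound 2 to compound 4 (0.01 log units; within the scatter). Compound 4 is thus expected to give about 75000 nM, in a range from 30000 nM to 200000 nM, with a real chance that the assay again reports only a limit.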

Compound 4, half-maximal inhibitory concentration: > 48000 nM
Compound 4: only a limit was reported (the forecaster's own chance of this, stated with the estimate: 60%); the middle value is on the limit's open side.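

In this assay compound 4 gives only a limit, > 48000 nM. No step from compound 2 to compound 4 can be read, because that limit is shared: the limit of > 48000 nM in this assay, at which 3 of the 4 values shown sit.

The compounds shown leave open whether hydrogen in place of methyl on an aromatic carbon changes the number in this assay at all.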